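Chloro on the ring of compound 3

The source may report more compounds than this note shows. Statements on the series, on what has been measured and on what is new or still open speak of the compounds shown alone.

Three compounds of this series carry a measurement in a functional assay on spleen for antagonist activity at Alpha-1B adrenergic receptor (Rattus norvegicus); a lower number here means a less potent compound, a higher number a more potent compound, by a factor of ten per unit of this negative logarithm. Compound 1 `COc1ccccc1N1CCN(CC2=NS(=O)(=O)c3ccccc3N2)CC1` gives 5.46 in this assay. Compound 2 `COc1ccccc1N1CCN(CC2=NS(=O)(=O)c3ccc(C)cc3N2)CC1` gives 6.05 in this assay. Compound 3 `COc1ccccc1N1CCN(CC2Nc3ccccc3S(=O)(=O)N2)CC1` gives 5.97 in this assay. Compound 3 therefore stands with compound 2, the two values being within the usual scatter of each other, and both stand clearly above the value of compound 1.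

Compound 4 `COc1ccccc1N1CCN(CC2Nc3cc(Cl)ccc3S(=O)(=O)N2)CC1` is not yet measured. It differs from compound 3 by chloro in place of hydrogen on an aromatic carbon. For the measured compounds named here, the only measured step of a kindred sort is a number 0.59 log units higher from compound 1 to compound 2 (beyond the scatter), which put a small group onto an aromatic carbon of the same shared core and raised the number beyond the scatter. Going by the values given here, no measured pair tells directly what a chloro group does on this ring, and the core of compound 3 differs from that of compound 1 in the way it is joined. Among the compounds with values here, still, the one step at hand points in a single direction, so a modest rise is expected for compound 4.

On that footing compound 4 is expected to give about 6.4 in this assay, that is an estimated step of a number 0.43 log units higher from compound 3 to compound 4 (beyond the scatter), with a range from 5.9 to 6.9.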

Compound 4, negative logarithm of the antagonist equilibrium constant: 5.09
The estimate for compound 4 lay 1.31 log units above the measured number, and the stated range ends above it.
By their numbers in this assay, from the lowest: compound 4; then compound 1; then compounds 3 and 2 (each within the scatter of the next).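

In this assay, chloro in place of hydrogen on an aromatic carbon of the six-membered aromatic ring of carbon only gives a number 0.88 log units lower from compound 3 to compound 4 (beyond the scatter), so on the core of compound 3 this change lowers potency beyond the scatter instead of raising it. For the compounds shown here, the only other substitution step, a number 0.59 log units higher from compound 1 to compound 2 (beyond the scatter), is methyl in place of hydrogen on an aromatic carbon and runs the opposite way, so the two steps together show no single direction for adding a group to an aromatic carbon, and since they differ in both group and core, neither difference can be singled out as what reverses the direction. The data at hand offer no measurement that accounts for the fall with chloro.

Still open, on these data alone, is whether the fall belongs to chloro itself or to this place on the ring, which methyl, fluoro or an amine at the same carbon of the core of compound 3 would separate. Also open, as far as these compounds go, is what chloro does on the core of compound 1, and whether chloro at the other aromatic carbons of the core of compound 3 gives a fall of similar size.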